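Removing a pentyl group from selenium: expected cytotoxicity

This account rests on a few compounds, and the source may have more. Where it says the series, first, only, none or still open, it means among the compounds named here.

Compound 1 `COc1ccc(CNc2nc([SeH])nc3ccccc23)cc1` gives > 100000 nM in an ADME assay on BEAS-2B cells (Homo sapiens) for cytotoxicity, read by MTT assay, with a stated time of 72 h; on this read-out higher numbers stand for weaker inhibition of growth and lower numbers for stronger inhibition of growth.
Compound 2 `CCCCC[Se]c1nc(NCc2ccc(SC)cc2)c2ccccc2n1` gives 88200 nM in this assay.

For compound 1 the result is a limit of the assay rather than a number. Compound 2 therefore provides the only number shown; the other value sits at the limit of > 100000 nM in this assay, at which 1 of the 2 values shown sits. Compound 3 `CSc1ccc(CNc2nc([SeH])nc3ccccc23)cc1` has not yet been measured. It differs from compound 2 by hydrogen in place of pentyl on a selenium, so that compound 3 carries the same selenium-bound hydrogen that compound 1 carries. For the measured compounds named here, no measured pair differing in that one place is available, so the size of the step is uncertain. Given that compound 1 gives only > 100000 nM, compound 3 is expected to remain very weak in this assay, with a step of a 1.1-fold higher number from compound 2 to compound 3 (0.03 log units; within the scatter) that may well lie within the scatter. The estimate for compound 3 is 95000 nM, with a range from 40000 nM to 250000 nM, and a fair chance that only a limit is reported.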

Compound 3, concentration for total growth inhibition: 58200 nM
Estimate against measurement, compound 3: 1.6-fold (0.21 log units) above, and the stated range covers the measured number.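

For the compounds shown here, this gives the first measured pair at this position: in this assay the step for hydrogen in place of pentyl on the selenium is a 1.5-fold lower number from compound 2 to compound 3 (0.18 log units; within the scatter), so the pentyl chain makes no difference that can be told apart from the scatter of repeated measurements. The second pair, with methylsulfanyl in place of methoxy on an aromatic carbon, shows an at least 1.7-fold lower number from compound 1 to compound 3 (0.23 log units; that floor lies within the scatter). That step is only a floor, since the value of compound 1 is a limit of the assay and not a number: the limit of > 100000 nM in this assay, at which 1 of the 3 values shown sits.

Going by these compounds, only hydrogen and pentyl appear on the selenium here, so it remains open whether a longer chain, a benzyl group or a chain ending in a carboxylic acid would give a number clearly apart from these. On these data alone, the true size of the step from methoxy to methylsulfanyl also remains open.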